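This account rests on a few compounds, and the source may have more. Where it says the series, first, only, none or still open, it means among the compounds named here.

Compound 1 `COc1ccccc1NS(=O)(=O)c1ccc(N2CCNC2=O)cc1` gives 300 nM in a functional assay on M21 cells (Homo sapiens) for antiproliferative activity, read by sulforhodamine B assay, with a stated time of 48 h; a lower number here means a stronger inhibitor, a higher number a weaker inhibitor.
Compound 2 `O=C1NCCN1c1ccc(S(=O)(=O)Nc2ccc(I)cc2)cc1` gives 260 nM.
Compound 3 `COc1cccc(NS(=O)(=O)c2ccc(N3CCNC3=O)cc2)c1` gives 65 nM.

Compound 3 has the lowest number of the three: the steps of a 4.6-fold lower number from compound 1 to compound 3 (0.66 log units; beyond the scatter) and a 4.0-fold lower number from compound 2 to compound 3 (0.60 log units; beyond the scatter) both lie beyond the scatter. Compound 4 `O=C1NCCN1c1ccc(S(=O)(=O)Nc2ccc(Cl)cc2)cc1` differs from compound 3 in one place: 4-chlorophenyl in place of 3-methoxyphenyl on a sulfonamide nitrogen. The step that bears most on this is a 4.0-fold lower number from compound 2 to compound 3 (0.60 log units; beyond the scatter), since compound 2 carries a 4-iodophenyl group and compound 4 a 4-chlorophenyl group, both without the acceptor of the 3-methoxyphenyl group. The step of a 1.2-fold lower number from compound 1 to compound 2 (0.06 log units; within the scatter) was within the scatter. Compound 4 is therefore expected to roughly reverse the step from compound 2 to compound 3 in this assay, with an expected step of a 3.8-fold higher number from compound 3 to compound 4 (0.59 log units; beyond the scatter). Compound 4 is estimated at 250 nM, within a range of 100 nM to 600 nM.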

Compound 4, half-maximal inhibitory concentration: 90 nM
Compound 4: the middle estimate sits 2.8-fold (0.44 log units) above what was measured; measured number below the stated range.
By their numbers in this assay, from the lowest: compounds 3 and 4 (each within the scatter of the next); then compounds 2 and 1 (each within the scatter of the next).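

At this sulfonamide nitrogen, a low number does not depend on the hydrogen-bond acceptor of the 3-methoxyphenyl group: 4-chlorophenyl has none, and the change gives a 1.4-fold higher number from compound 3 to compound 4 (0.14 log units; within the scatter). Iodo and chloro on an aromatic carbon are not interchangeable here, with a 2.9-fold lower number from compound 2 to compound 4 (0.46 log units; beyond the scatter), and replacing 2-methoxyphenyl with 4-chlorophenyl gives a 3.3-fold lower number from compound 1 to compound 4 (0.52 log units; beyond the scatter). No evidence is available to explain these differences.

Going by these compounds, it remains open how an amine or a carboxylic acid on the phenyl ring would fare at this sulfonamide nitrogen.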